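The compounds below may be only part of what the source reports. "The series", "measured", "known", "first", "only" and "open" are said of these compounds alone.

Working notes on the series. One core runs unchanged through compound 1 `CCN(CC)c1ccc2cc(C(=O)c3ccc(N4CCN(C(=O)CN5CCN(C(=O)CCl)CC5)CC4)cc3)oc2c1`, compound 2 `CCN(CC)c1ccc2cc(C(=O)c3ccc(N4CCN(C(=O)CN5CCN(S(=O)(=O)C6CC6)CC5)CC4)cc3)oc2c1`, compound 3 `CCN(CC)c1ccc2cc(C(=O)c3ccc(N4CCN(C(=O)CN5CCN(S(=O)(=O)c6ccc(OC(F)(F)F)cc6)CC5)CC4)cc3)oc2c1` and the still unmeasured compound 4 `CCN(CC)c1ccc2cc(C(=O)c3ccc(N4CCN(C(=O)CN5CCN(Cc6ccc(F)c(F)c6)CC5)CC4)cc3)oc2c1`; the four differ only in the group carried on an amine nitrogen in a ring. In an ADME assay on L02 cells (Homo sapiens) for cytotoxicity, read by MTT assay, with a stated time of 48 h (on this read-out higher numbers stand for weaker inhibition and lower numbers for stronger inhibition), compound 1 gives 20900 nM and compound 3 gives 34700 nM. For compound 2 the read-out in this assay is a limit, > 100000 nM, and no number. Compound 2 therefore stands at the weak-inhibition end of the series, sitting at the limit of > 100000 nM in this assay, at which 1 of the 3 values shown sits, with both neighbours clearly below it: an at least 4.7-fold higher number from compound 1 to compound 2 (0.67 log units; beyond the scatter) and an at least 2.8-fold lower number from compound 2 to compound 3 (0.45 log units; beyond the scatter). Both measured steps show that swapping the cyclopropylsulfonyl of compound 2 for another group returns a number under the limit. Compound 4 carries the change (3,4-difluorobenzyl in place of cyclopropylsulfonyl on an amine nitrogen in a ring). For the measured compounds named here, no measured step tests a benzyl group on this nitrogen, so the size is uncertain, but a downward step of about an at least 3.3-fold lower number from compound 2 to compound 4 (0.52 log units; beyond the scatter) is expected, beyond the scatter. Compound 4 is thus expected to give 30000 nM in this assay, with a range of 10000 nM to 100000 nM.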

Compound 4, half-maximal inhibitory concentration: 10200 nM
Estimate against measurement, compound 4: 2.9-fold (0.47 log units) above; the range from low to high includes it.
By their numbers in this assay, from the lowest: compound 4; then compounds 1 and 3 (each within the scatter of the next). At a limit, above all of these: compound 2.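

For the compounds shown here, the 3,4-difluorobenzyl group is the first group on this amine nitrogen joined through neither a sulfonyl nor a carbonyl, and in this assay this change gives an at least 9.8-fold lower number from compound 2 to compound 4 (0.99 log units; beyond the scatter). Set against the (chloromethyl)carbonyl group, the same benzyl group gives a 2.0-fold lower number from compound 1 to compound 4 (0.31 log units; beyond the scatter), a modest step, so a number at this level does not need that group. The value of compound 2 is a limit and not a number, so the first step gives only a bound on the size of the change: the limit of > 100000 nM in this assay, at which 1 of the 4 values shown sits.

The compounds shown leave open whether the fall in the number comes with the benzyl group itself or needs its two fluorines, which an unsubstituted benzyl would separate. On these data alone, how a longer alkyl chain, a carboxylic acid or a basic amine on this nitrogen would read in this assay also stays open.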